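Swapping an Ether Tail for a Benzyl Group

The compounds below may be only part of what the source reports. "The series", "measured", "known", "first", "only" and "open" are said of these compounds alone.

Of the compounds shown here, three sharing a common core have been measured in an assay for inhibition of 15-hydroxyprostaglandin dehydrogenase [NAD(+)] (Homo sapiens), read by fluorescence and spectrophotometry; a lower number here means a stronger inhibitor, a higher number a weaker inhibitor. Compound 1 `O=C1NC(=O)/C(=C/c2ccc(OCCC3CCCC3)cc2Cl)S1` gives 42 nM, and compound 3 `O=C1NC(=O)/C(=C/c2ccc(OCC3CCC3)c(Cl)c2)S1` gives 9 nM. Compound 2 `CC(C)OCCOc1ccc(/C=C2\SC(O)=NC2=O)cc1Cl` stands at the top of the three with 2740 nM, the highest number of the set; the gap to compound 1 is beyond the usual scatter, and the gap to compound 3 is wider still. Compound 2 is therefore the weakest inhibitor among the measured three.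

Compound 4 `O=C1N=C(O)S/C1=C\c1ccc(OCCCc2ccccc2)c(Cl)c1` has not yet been measured. It differs from compound 2 in one place: benzyl in place of isopropoxy on a saturated chain carbon, two bonds along the chain from an oxygen on an aromatic ring. Within the data shown here, no measured pair in the set isolates this change, so its effect must be inferred. The two compounds that carry a ring-bearing tail on the same aryl ether, compound 1 at 42 nM and compound 3 at 9 nM, both sit far below compound 2, and compound 4 likewise carries a ring at the end of its chain.

The step from compound 2 to compound 4 is expected to be a large move toward a lower number, a 46-fold lower number from compound 2 to compound 4 (1.66 log units; beyond the scatter). Compound 4 is expected to give about 60 nM, within a range of 10 nM to 400 nM.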

Compound 4, half-maximal inhibitory concentration: 38 nM
Beside the measured number, compound 4's estimate is 1.6-fold (0.20 log units) above it; the range from low to high includes it.
By their numbers in this assay, from the lowest: compound 3; then compounds 4 and 1 (each within the scatter of the next); then compound 2.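

In this assay, the change of benzyl in place of isopropoxy on a saturated chain carbon, two bonds along the chain from an oxygen on an aromatic ring, gives a 72-fold lower number from compound 2 to compound 4 (1.86 log units; beyond the scatter), a large step beyond the scatter. Among these compounds, this is the only direct reading of a change at this position: the earlier compounds differ from one another in more than one place, so they could not tie a difference in number to this part of the chain alone. Here the isopropoxy, with its oxygen and no ring, gives way to a benzyl carrying a six-membered aromatic ring of carbon only, and this position proves able to move the number a long way, though no evidence shown accounts for the size of the step.

The loss of the oxygen and the arrival of the aromatic ring come together in this one step, so the compounds shown cannot separate the two. A cyclohexylmethyl group or a plain butyl chain at the same carbon would be needed to tell them apart, and a pyridylmethyl group would test whether the ring must be of carbon only.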